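From compound 1 to compound 3: losing the allyl group

The compounds below may be only part of what the source reports. "The series", "measured", "known", "first", "only" and "open" are said of these compounds alone.

Compound 1 `C=CCn1c(-c2ccc(OC)cc2COCOC)cc2ccccc2c1=O`: > 100000 nM (a limit of the assay)
Compound 2 `C=CCn1c(-c2cc(OC)c(OC)cc2COCOC)cc2ccccc2c1=O`: 88100 nM

Both results come from a functional assay on A549 cells (Homo sapiens) for cytotoxicity, read by MTT assay, with a stated time of 48 h; on this read-out lower numbers stand for stronger inhibition and higher numbers for weaker inhibition. Compound 1 sits at the limit of > 100000 nM in this assay, at which 1 of the 2 values shown sits, so it has a limit and not an exact number. Among the measured compounds shown here, the only measured step, an at least 1.1-fold lower number from compound 1 to compound 2 (0.05 log units; that floor lies within the scatter), is a methoxy in place of hydrogen on an aromatic carbon, and its floor lies within the scatter.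

Compound 3 `COCOCc1cc(OC)ccc1-c1cc2ccccc2c(=O)[nH]1` has not been measured yet. It differs from compound 1 by hydrogen in place of allyl on an aromatic nitrogen. For the measured compounds named here, the measured step changes another place in the molecule, so it bears on this change only indirectly, and no measured pair shows what removing the allyl group does. The nearest real number is that of compound 2, 88100 nM, so the estimate stays close to it. In this assay no clear step is expected, only a small one at most, towards a slightly lower number. The expected step is an at least 1.1-fold lower number from compound 1 to compound 3 (0.04 log units; that floor lies within the scatter). Compound 3 is expected at about 90000 nM. The estimated range for compound 3 runs from 30000 nM to 200000 nM.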

Compound 3, half-maximal inhibitory concentration: 45300 nM
Estimate against measurement, compound 3: 2.0-fold (0.30 log units) above; the range from low to high includes it.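

In this assay, hydrogen in place of allyl on the aromatic nitrogen gives an at least 2.2-fold lower number from compound 1 to compound 3 (0.34 log units; beyond the scatter). Unlike the methoxy change on the aromatic carbon, whose floor stayed within the scatter, this change at the aromatic nitrogen produces a step that can be told apart from the noise, so this position does affect the read-out and the allyl group is not needed for the cytotoxicity seen here. Compound 1 carries only a limit, so the step is a floor and its real size could be larger: the limit of > 100000 nM in this assay, at which 1 of the 3 values shown sits.

Going by these compounds, this rests on a single pair of compounds, so it remains open whether a methyl group, a propyl chain or a benzyl group on that nitrogen would read closer to compound 1 or to compound 3, and whether the number depends on the size of the group or on something else about allyl. On these data alone, it is also open whether the same change on the core of compound 2, with its extra methoxy group, would produce a step of similar size.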